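The compounds below may be only part of what the source reports. "The series", "measured", "known", "first", "only" and "open" are said of these compounds alone.

Measured compounds:
compound 1 `COc1cc(-c2ncncc2-c2ccc(SC)cc2)cc(OC)c1OC` — 220 nM
compound 2 `CCOc1ccc(-c2cncnc2-c2cc(OC)c(OC)c(OC)c2)cc1C(F)(F)F` — 790 nM

In a functional assay on HeLa cells (Homo sapiens) for antiproliferative activity, read by CCK-8 assay, with a stated time of 72 h (on this read-out higher numbers stand for weaker inhibition and lower numbers for stronger inhibition), compound 1 holds the lower of the two numbers, and compound 2 sits a good deal higher, a gap beyond the usual scatter. Compound 3 `COc1cc(-c2ncncc2-c2ccc(Br)cc2)cc(OC)c1OC` differs from compound 1 by bromo in place of methylsulfanyl on an aromatic carbon. Going by the values given here, no step between measured compounds covers this change, so only a modest shift is expected, leaning toward weaker inhibition; the estimated step of a 1.8-fold higher number from compound 1 to compound 3 (0.26 log units; within the scatter) is expected to stay close to the scatter. Compound 3 is therefore expected to give 400 nM, within a range from 120 nM to 1500 nM.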

Compound 3, half-maximal inhibitory concentration: 500 nM
The estimate for compound 3 lay 1.3-fold (0.10 log units) below the measured number; the range from low to high includes it.
By their numbers in this assay, from the lowest: compound 1; then compounds 3 and 2 (each within the scatter of the next).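

In this assay, going by these compounds alone, this is the first step between compounds that differ in one place: the change from 4-(methylsulfanyl)phenyl to 4-bromophenyl gives a 2.3-fold higher number from compound 1 to compound 3 (0.36 log units; beyond the scatter) and is modest, yet beyond the scatter. The group on this aromatic carbon, para to a large group, therefore moves the read-out, and bromo does not match methylsulfanyl here. No measurement at hand explains this step.

Still open, from the compounds shown here alone, is how an amine, a carboxylic acid or a longer chain such as ethylsulfanyl would fare at this place.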